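Amide-capped series: oxazole versus carboxyalkyl cap, exposure

The compounds below may be only part of what the source reports. "The series", "measured", "known", "first", "only" and "open" are said of these compounds alone.

Measured so far:
compound 1, `COc1ccc2c(c1)CCN(C(=O)c1cc(O)no1)[C@H]2C(=O)Nc1cc(F)c([Si](C)(C)C)c(F)c1` — 200000 ng.h/mL
compound 2, `COc1ccc2c(c1)CCN(C(=O)CCC(=O)O)[C@H]2C(=O)Nc1cc(F)c([Si](C)(C)C)c(F)c1` — 2500000 ng.h/mL

In an ADME assay on the whole organism for pharmacokinetics, with Mus musculus as the target, read by LC-MS, using cassette dosing, with a stated time of 8 h, at a dose of 1 mg/kg by the oral route (a higher number here means more compound in the circulation at the dose given, a lower number less compound in the circulation), compound 1 stands lowest of the two numbers measured; the nearest is compound 2, reached by a 13-fold higher number from compound 1 to compound 2 (1.10 log units; beyond the scatter). That step swaps the 3-hydroxy-1,2-oxazol-5-yl for 2-carboxyethyl on a carbonyl carbon.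

Compound 3, `COc1ccc2c(c1)CCN(C(=O)CCCCC(=O)O)[C@H]2C(=O)Nc1cc(F)c([Si](C)(C)C)c(F)c1`, is not yet measured. It differs from compound 1 as follows: 4-carboxybutyl in place of 3-hydroxy-1,2-oxazol-5-yl on a carbonyl carbon. Among the compounds with values here, the only measured step that bears on it is the one from compound 1 to compound 2, which also replaces the 3-hydroxy-1,2-oxazol-5-yl with a carboxyalkyl chain on the same carbonyl carbon; compound 3 carries a longer chain of that kind. A step in this assay of the same direction and of broadly similar size is therefore expected, a 7.5-fold higher number from compound 1 to compound 3 (0.88 log units; beyond the scatter), with the chain length difference leaving room for a somewhat smaller or larger shift. Compound 3 is estimated at 1500000 ng.h/mL, within a range from 400000 ng.h/mL to 5000000 ng.h/mL.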

Compound 3, area under the concentration-time curve: 1030000 ng.h/mL
The estimate for compound 3 lay 1.5-fold (0.16 log units) above the measured number; the range from low to high includes it.
By their numbers in this assay, from the lowest: compound 1; then compound 3; then compound 2.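

In this assay the 4-carboxybutyl group on the carbonyl carbon also gives a higher number than the 3-hydroxy-1,2-oxazol-5-yl group (a 5.2-fold higher number from compound 1 to compound 3 (0.71 log units; beyond the scatter)), so the rise seen with 2-carboxyethyl is not confined to that one chain. Chain length also counts at this position (a 2.4-fold lower number from compound 2 to compound 3 (0.39 log units; beyond the scatter)), and of the two chains shown the shorter gives the higher number, so the two carboxyalkyl groups are not interchangeable here. Nothing available explains either step.

As far as these compounds go, two chain lengths do not establish a trend, so it remains open whether a 3-carboxypropyl chain would fall between compound 2 and compound 3 or whether a still longer chain would continue the fall. Also open, from the compounds shown here alone, is whether a methyl ester or a primary amide at the chain end would keep the higher numbers that the terminal carboxylic acid compounds show.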